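A Trifluoromethyl Substituent Weighed Against One Earlier Step

This account rests on a few compounds, and the source may have more. Where it says the series, first, only, none or still open, it means among the compounds named here.

Compound 1, `Cn1c(CN2CCC(c3ccccc3)CC2)nc2ccccc21`, gives 200 nM in an assay on CHO cells with metabotropic glutamate receptor 2 (Homo sapiens) as the target, read by FLIPR; a lower number here means that less compound is needed, a higher number that more compound is needed for the effect.
Compound 2, `Cn1c(CN2CCC(c3ccc(Cl)cc3)CC2)nc2ccccc21`, gives 79.4 nM in this assay.

Compound 1 stands highest of the two numbers; its nearest neighbour is compound 2, reached through a 2.5-fold lower number from compound 1 to compound 2 (0.40 log units; beyond the scatter), a modest move brought by a chloro in place of hydrogen on an aromatic carbon.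

Compound 3, `Cn1c(CN2CCC(c3cccc(C(F)(F)F)c3)CC2)nc2ccccc21`, has not yet been measured. It differs from compound 1 by trifluoromethyl in place of hydrogen on an aromatic carbon. Among the compounds with values here, only the step from compound 1 to compound 2 bears on this change, and it shows that putting a small group onto that aromatic ring lowered the number modestly. The new group sits at a different place on the ring and is a different group, so the earlier step is only a loose guide. Compound 3 is therefore expected to give 125 nM, within 40 nM to 400 nM, which amounts to an expected 1.6-fold lower number from compound 1 to compound 3 (0.20 log units; within the scatter), a shift that may not exceed the scatter.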

Compound 3, half-maximal effective concentration: 100 nM
Compound 3: middle estimate off by 1.3-fold (0.10 log units), on the high side; the range from low to high includes it.
By their numbers in this assay, from the lowest: compounds 2, 3 and 1 (each within the scatter of the next, the first and the last beyond it).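

Replacing hydrogen with trifluoromethyl, on an aromatic carbon meta to a large group, brings a 2.0-fold lower number from compound 1 to compound 3 (0.30 log units; within the scatter) in this assay and so cannot be told apart from hydrogen at this place. Within the data shown here, this is the first look at this position and at a group of this size, and it shows that the four heavy atoms of trifluoromethyl can sit here without a clear change in the number, in either direction. Nothing measured here accounts for this result.

The compounds shown hold trifluoromethyl at this one place only, so it remains open whether the same group on another carbon of the ring would give a number beyond the scatter from compound 1. Going by these compounds, it is also open whether a different group at this place, such as an amine, a carboxylic acid or a longer chain, would do so.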